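Replacing the Aryl Ether of Compound 3

A few compounds are considered here, and "the series" means these few. Any claim that something is new, unique, unknown or untested is made for them only; others in the source may bear on it.

Three members of one series, all built on the shared core and differing only in the aryl group on the ether oxygen, have so far been tested. In an ADME assay on microsomes from liver (Rattus norvegicus) for metabolic stability (a lower number here means slower removal, a higher number faster removal of the compound), compound 1 `O=S(=O)(CC1CC1)c1nnc(-c2cc(F)c(-c3cnc(Oc4ccc(F)cc4F)c(Cl)c3)cc2F)[nH]1` gives 22 uL/min. Compound 2 `Cc1ccc(Cl)c(Oc2ncc(-c3cc(F)c(-c4nnc(S(=O)(=O)CC5CC5)[nH]4)cc3F)cc2Cl)c1`, bearing a 2-chloro-5-methylphenyl on that oxygen, gives 52 uL/min in this assay. Compound 3 `O=S(=O)(CC1CC1)c1nnc(-c2cc(F)c(-c3cnc(Oc4ccccc4C(F)(F)F)c(Cl)c3)cc2F)[nH]1`, carrying a 2-(trifluoromethyl)phenyl, returns only a limit in this assay, < 14 uL/min, so its position is known just as a ceiling (the limit of < 14 uL/min in this assay, at which 1 of the 3 values shown sits). The measured steps into compound 3 are an at least 1.5-fold lower number from compound 1 to compound 3 (0.19 log units; that floor lies within the scatter) and an at least 3.7-fold lower number from compound 2 to compound 3 (0.56 log units; beyond the scatter).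

Compound 4 `O=S(=O)(CC1CC1)c1nnc(-c2cc(F)c(-c3cnc(Oc4ccc(F)cc4Cl)c(Cl)c3)cc2F)[nH]1` introduces (2-chloro-4-fluorophenyl in place of 2-(trifluoromethyl)phenyl on an oxygen on an aromatic ring). The two steps that bear on this change both ran toward lower numbers when the 2-(trifluoromethyl)phenyl entered, so its departure is expected to run the other way, and the entering 2-chloro-4-fluorophenyl most resembles the 2,4-difluorophenyl of compound 1, whose value was 22 uL/min. Compound 4 is therefore expected to give about 22 uL/min, with a range from 11 uL/min to 45 uL/min. The expected move is an at least 1.5-fold higher number from compound 3 to compound 4 (0.19 log units; that floor lies within the scatter), a rise of modest size at most.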

Compound 4, intrinsic clearance in a liver preparation (reported as CLH), per the amount of preparation that the assay uses: 53 uL/min
Beside the measured number, compound 4's estimate is 2.4-fold (0.38 log units) below it, outside the stated range (above it).
By their numbers in this assay, from the lowest: compound 1; then compounds 2 and 4 (each within the scatter of the next). At a limit, below all of these: compound 3.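

Compound 1 and compound 4 differ only by chloro in place of fluoro on an aromatic carbon, and in this assay that single exchange gives a 2.4-fold higher number from compound 1 to compound 4 (0.38 log units; beyond the scatter), so a change of one halogen on this ring is enough to separate two close analogues. The 2-chloro-4-fluorophenyl and the 2-chloro-5-methylphenyl on the ether oxygen cannot be told apart, with a 1.0-fold higher number from compound 2 to compound 4 (0.01 log units; within the scatter), which means that in these two compounds the fluoro and the methyl make no difference that can be read beyond the scatter. Removing the 2-(trifluoromethyl)phenyl gives an at least 3.7-fold higher number from compound 3 to compound 4 (0.57 log units; beyond the scatter), and this figure is only a floor, as compound 3 is known solely as a limit: the limit of < 14 uL/min in this assay, at which 1 of the 4 values shown sits.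

Going by these compounds, what remains open is how far compound 3 really lies from the others, and whether the low number it shows belongs to the trifluoromethyl group itself or would also appear with another group in its place. The aryl groups shown carry only halogens, methyl and trifluoromethyl, so a nitrile, a methoxy or an amine on this ring remains an untested question here, as does an ether oxygen bearing something other than a phenyl.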